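Compound 3 at the Limit, and a Chloro Group

The compounds below may be only part of what the source reports. "The series", "measured", "known", "first", "only" and "open" are said of these compounds alone.

Measured in a functional assay on HL-60 cells (Homo sapiens) for antiproliferative activity, read by MTT assay, with a stated time of 72 h; a lower number here means a stronger inhibitor, a higher number a weaker inhibitor:
compound 1 `COc1cc(-n2ncnc2-c2ccc(C)cc2)cc(OC)c1OC`: 90 nM
compound 2 `COc1cccc(-c2ncnn2-c2cc(OC)c(OC)c(OC)c2)c1`: > 10000 nM (a limit)
compound 3 `COc1cc(-n2ncnc2-c2ccccc2)cc(OC)c1OC`: > 10000 nM (a limit)

Compound 3 stands at the limit of > 10000 nM in this assay, at which 2 of the 3 values shown sit, so it has a limit and no number. Compound 4 `COc1cc(-n2ncnc2-c2cccc(Cl)c2)cc(OC)c1OC` carries chloro in place of hydrogen on an aromatic carbon, phenyl to 3-chlorophenyl: chloro in place of hydrogen on an aromatic carbon. For the measured compounds named here, two measured steps bear on this change. The first is an at least 110-fold higher number from compound 1 to compound 3 (2.04 log units; beyond the scatter), with hydrogen in place of methyl. The second is an at least 110-fold higher number from compound 1 to compound 2 (2.04 log units; beyond the scatter), with 3-methoxyphenyl in place of 4-methylphenyl. The 3-chlorophenyl group therefore promises little, and only a modest move toward a lower number is expected. The expected change is an at least 2.0-fold lower number from compound 3 to compound 4 (0.30 log units; that floor lies within the scatter). For compound 4 the estimated value is 5000 nM, with an expected range of 500 nM to 10000 nM.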

Compound 4, half-maximal inhibitory concentration: > 10000 nM
Compound 4: only a limit was reported; the forecaster's own chance of this, stated with the estimate: 55%; at least 2.0-fold (0.30 log units) between middle value and limit.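

In this assay the step reads an at least 110-fold higher number from compound 1 to compound 4 (2.04 log units; beyond the scatter), so chloro on this aromatic carbon, meta to a large group, does not recover what the 4-methylphenyl group of compound 1 gives. Compound 4 has only a limit, and the steps among compound 2, compound 3 and compound 4 cannot be read, so any effect of chloro in place of hydrogen stays hidden: the limit of > 10000 nM in this assay, at which 3 of the 4 values shown sit.

From the compounds shown here alone, whether chloro would hold up in the place methyl occupies in compound 1 remains open. So does what an ethyl group or an amine would do there.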